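This account rests on a few compounds, and the source may have more. Where it says the series, first, only, none or still open, it means among the compounds named here.

Four close relatives share a thiourea linked through a sulfur-bridged pyridine amide, and three of them have been tested. Compound 1 `CNC(=O)c1ccc(Sc2cccc(NC(=S)Nc3ccc(F)c(C(F)(F)F)c3)c2)nc1` and compound 2 `CNC(=O)c1ccc(Sc2cccc(NC(=S)Nc3ccc(F)c(F)c3)c2)nc1` carry one arrangement of the core; compound 3 `CNC(=O)c1ccc(Sc2ccc(NC(=S)Nc3ccc(F)c(C(F)(F)F)c3)cc2)nc1` and compound 4 `CNC(=O)c1ccc(Sc2ccc(NC(=S)Nc3ccc(F)c(F)c3)cc2)nc1` carry another, and the difference between the two cores is not broken down here.

In a functional assay on B16-BL6 cells (Mus musculus) for cytotoxicity, read by MTT assay, with a stated time of 48 h (a lower number here means a stronger inhibitor, a higher number a weaker inhibitor), compound 1 gives 42400 nM, and compound 2 gives 58200 nM. The change between them is fluoro in place of trifluoromethyl on an aromatic carbon, and it gave a 1.4-fold higher number from compound 1 to compound 2 (0.14 log units; within the scatter). In this assay compound 3 gives 29300 nM, a number that sits within the scatter of both compound 1 and compound 2.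

Compound 4 is reached from compound 3 by the same change, (fluoro in place of trifluoromethyl on an aromatic carbon), at the same surroundings on the ring. Among the measured compounds shown here, with only one earlier example of this swap, the best guide is that earlier step, and because it was a 1.4-fold higher number from compound 1 to compound 2 (0.14 log units; within the scatter) the expected step here is a 1.4-fold higher number from compound 3 to compound 4 (0.15 log units; within the scatter). On that basis compound 4 is expected to give about 41000 nM, most likely between 20000 nM and 85000 nM.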

Compound 4, half-maximal inhibitory concentration: 52600 nM
The estimate for compound 4 lay 1.3-fold (0.11 log units) below the measured number; low and high end bracket the measured number.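

In this assay the swap of trifluoromethyl for fluoro gave a 1.8-fold higher number from compound 3 to compound 4 (0.25 log units; within the scatter), so on this second core it again produced no change that can be told apart from the scatter. The two steps agree, as far as such small steps can: the same change on two cores in this assay, a 1.4-fold higher number (0.14 log units; within the scatter) from compound 1 to compound 2 and a 1.8-fold higher number (0.25 log units; within the scatter) from compound 3 to compound 4, 1.3-fold (0.12 log units) apart, within the scatter of two such steps. This shows that, on these two cores, the swap behaves alike in this one assay, but since neither step stands clear of the scatter, it does not show that the swap truly weakens the compounds, or that a real effect of this change carries from one core to the other.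

On these data alone, whether a group such as chloro, methoxy or an amine at the same place on the ring would move the number beyond the scatter remains open. So does whether replacing the thiourea with a urea, which has a carbonyl in place of the sulfur-bearing carbon, would give a step large enough to compare across the two cores.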